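Aryl swap on the shared core: tolerated concentration

The source may report more compounds than this note shows. Statements on the series, on what has been measured and on what is new or still open speak of the compounds shown alone.

Compound 1 `Cc1oc(-c2ccccc2Cl)nc1CN1CCC(C(=O)NCCCN2C[C@H](C)C[C@H](C)C2)CC1` stands second highest of the three numbers in an ADME assay on Huh7.5.1 cells (Homo sapiens) for cytotoxicity, read by ATP content, with a stated time of 48 h (a higher number here means that more compound is tolerated, a lower number that less compound is tolerated), giving 16500 nM. Compound 3 `Cc1ccccc1-c1nc(CN2CCC(C(=O)N3CCN(C4CCN(C)CC4)CC3)CC2)c(C)o1` gives 19900 nM, within the scatter of compound 1, and compound 2 `Cc1ccccc1-c1nc(CN2CCC(C(=O)NCCCN3CCC(C)(C)CC3)CC2)c(C)o1` gives 10200 nM, also within the scatter. The three values cluster closely and show no order.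

Compound 4 `Cc1cccc(C)c1-c1nc(CN2CCC(C(=O)NCCCN3C[C@H](C)C[C@H](C)C3)CC2)c(C)o1` awaits measurement. It differs from compound 1 in one place: 2,6-dimethylphenyl in place of 2-chlorophenyl on an aromatic carbon. Among the compounds with values here, no step between measured compounds bears on this change, and the measured values leave no trend to lean on. The step of a 1.0-fold lower number from compound 1 to compound 4 (0.01 log units; within the scatter) is therefore expected to stay within the scatter, with no direction favoured. Compound 4 is estimated at 16000 nM, with a range from 7500 nM to 34000 nM.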

Compound 4, half-maximal cytotoxic concentration: 21000 nM
Estimate against measurement, compound 4: 1.3-fold (0.12 log units) below; low and high end bracket the measured number.
By their numbers in this assay, from the lowest: compounds 2, 1, 3 and 4 (each within the scatter of the next, the first and the last beyond it).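

In this assay, within the data shown here, 2,6-dimethylphenyl in place of 2-chlorophenyl on this aromatic carbon gives a 1.3-fold higher number from compound 1 to compound 4 (0.10 log units; within the scatter), the first one-place step. On the core of compound 1, this position therefore accepts the change of aryl group with the number staying within the scatter. No measured evidence on the reason for this result is available.

As far as these compounds go, an unsubstituted phenyl or a pyridine ring at this position remains open. So does whether the same change stays within the scatter with the other amide side chains in the series.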